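Adding (2-hydroxyethyl)amino to compound 3

A few compounds are considered here, and "the series" means these few. Any claim that something is new, unique, unknown or untested is made for them only; others in the source may bear on it.

Of the compounds shown here, three have been measured in a functional assay on SNU-638 cells (Homo sapiens) for inhibition, read by sulforhodamine B assay, with a stated time of 2 days; a higher number here means a weaker inhibitor of growth, a lower number a stronger inhibitor of growth. Compound 3 `Cc1c(C#N)c(Nc2ccc(S(N)(=O)=O)cc2)nc2ncnc(N)c12` gives 6200 nM and compound 2 `N#Cc1cc2c(N)ncnc2nc1Nc1ccc(S(N)(=O)=O)cc1` gives 7570 nM, two values within the scatter of each other. Compound 1 `Cc1c(C#N)c(NCCO)nc2nc(NCCO)nc(N)c12` stands apart at 18200 nM, a higher number than compound 3 shows, by more than the scatter. Compound 3 therefore sits at the low end of this small set, level with compound 2.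

Compound 4 `Cc1c(C#N)c(Nc2ccc(S(N)(=O)=O)cc2)nc2nc(NCCO)nc(N)c12` differs from compound 3 in one place: (2-hydroxyethyl)amino in place of hydrogen on an aromatic carbon. It carries (2-hydroxyethyl)amino in place of hydrogen on an aromatic carbon, between two ring nitrogen atoms. Among the measured compounds shown here, no measured step shows this change alone. For the measured compounds named here, the only measured step, a 1.2-fold lower number from compound 2 to compound 3 (0.09 log units; within the scatter), is methyl in place of hydrogen at a different place, so it offers little guidance. Compound 1 also carries (2-hydroxyethyl)amino at this place and gives 18200 nM, but it differs from compound 3 elsewhere too, so that value cannot be read as the size of this change. It does leave the higher side more open. No step beyond the scatter is expected in this assay, and the expected step is a 1.1-fold higher number from compound 3 to compound 4 (0.05 log units; within the scatter). For compound 4 the estimated value is 7000 nM, with an expected range of 2500 nM to 18000 nM.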

Compound 4, concentration for 50% growth inhibition: 17100 nM
Beside the measured number, compound 4's estimate is 2.4-fold (0.39 log units) below it; the measured number falls inside the stated range.
By their numbers in this assay, from the lowest: compounds 3 and 2 (each within the scatter of the next); then compounds 4 and 1 (each within the scatter of the next).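

In this assay, among the compounds shown here, the change appears on its own for the first time, as a 2.8-fold higher number from compound 3 to compound 4 (0.44 log units; beyond the scatter), so this aromatic carbon between two ring nitrogen atoms is not indifferent to (2-hydroxyethyl)amino: the group moves the number upward, toward weaker inhibition of growth, by a modest step beyond the scatter. Compound 4 now stands with compound 1, which carries the same group at this place and differs from it in one other place: compound 4 gives 17100 nM and compound 1 gives 18200 nM, two values within the scatter of each other. The data offer no measured explanation for the step.

As far as these compounds go, what remains open is whether the step belongs to (2-hydroxyethyl)amino in particular or to any substituent replacing hydrogen here, since a single group on a single background cannot separate the two. A methylamino group, a longer chain such as (3-hydroxypropyl)amino, or a carboxylic acid at this place could settle that, and the same change on the core of compound 2, which lacks the methyl group, would show whether the step carries over.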